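The compounds below may be only part of what the source reports. "The series", "measured", "known", "first", "only" and "open" are said of these compounds alone.

Compound 1 `CNc1ncnc2c1c(-c1ccccc1)cn2[C@@H]1O[C@H](CO)[C@@H](O)[C@H]1O` carries a phenyl group on the shared core. In a functional assay on HeLa S3 cells (Homo sapiens) for antiproliferative activity, read by XTT assay, with a stated time of 72 h (on this read-out higher numbers stand for weaker inhibition and lower numbers for stronger inhibition), compound 1 reaches only the limit of the measurement, > 20000 nM. Compound 2 `CNc1ncnc2c1c(-c1ccsc1)cn2[C@@H]1O[C@H](CO)[C@@H](O)[C@H]1O` differs from it by thiophen-3-yl in place of phenyl on an aromatic carbon and likewise gives only a limit in this assay, > 20000 nM, so the step that the two limits leave unreadable from compound 1 to compound 2 cannot be sized. Compound 3 `Nc1nc2c(c(-c3ccccc3)cn2[C@@H]2O[C@H](CO)[C@@H](O)[C@H]2O)c(=O)[nH]1` has a different core, and the difference between the two cores is not broken down here; in this assay compound 3 also stops at a limit, > 20000 nM. Compound 4 `Nc1nc2c(c(-c3ccsc3)cn2[C@@H]2O[C@H](CO)[C@@H](O)[C@H]2O)c(=O)[nH]1`, not yet measured, differs from compound 3 by thiophen-3-yl in place of phenyl on an aromatic carbon, the same change as from compound 1 to compound 2. Because the limit of > 20000 nM in this assay, at which 3 of the 3 values shown sit, shows all three measured values sitting at the limit, the expected step is a step that the limit leaves unreadable from compound 3 to compound 4. Compound 4 is therefore estimated at 30000 nM, between 8000 nM and 100000 nM.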

Compound 4, half-maximal inhibitory concentration: > 20000 nM
Compound 4: only a limit was reported; the forecaster's own chance of this, stated with the estimate: 85%; the middle value lies beyond the limit too.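

Compound 3 and compound 4 both give only a limit, so the size of the change from phenyl to thiophen-3-yl cannot be read: the limit of > 20000 nM in this assay, at which 4 of the 4 values shown sit. Going by these compounds, how strongly any of the four compounds acts in this assay, and whether these two groups differ there at all, stays open.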